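The source may hold more compounds than are shown below. What is called first, only, known or untested is meant among the compounds shown, and "the series" means these compounds.

Compounds measured:
- compound 1 `O=C(O)c1csc([C@H]2CC[C@@H]3[C@@H](COc4ccccc4F)[C@H](O)C[C@@H]3O2)n1`: 23 nM
- compound 2 `O=C(O)c1csc([C@H]2CC[C@@H]3[C@@H](/C=C/CCOc4ccccc4)[C@H](O)C[C@@H]3O2)n1`: 3.9 nM
- compound 3 `O=C(O)CCC[C@H]1CC[C@@H]2[C@@H](/C=C/[C@@H](O)COc3ccccc3)[C@H](O)C[C@@H]2O1`: 8900 nM

Three compounds sharing a bicyclic ether core were tested in a functional assay on CHO cells for agonist activity at prostaglandin E2 receptor EP2 subtype (Homo sapiens), read by HTRF and cAMP accumulation, with a stated time of 30 min; a lower number here means that less compound is needed, a higher number that more compound is needed for the effect. Compound 1 gives 23 nM and stands second highest of the three numbers. Compound 2 gives 3.9 nM, and its gap to compound 1 lies beyond the scatter, while compound 3 gives 8900 nM, a gap to compound 1 that also lies beyond the scatter and is by far the larger of the two. Among the compounds with values here, compounds 2 and 3 differ from compound 1 in several places at once, so no single step between measured compounds is available.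

Compound 4 `O=C(O)c1csc([C@H]2CC[C@@H]3[C@@H](COc4ccccc4Cl)[C@H](O)C[C@@H]3O2)n1` has not yet been measured in this assay. It differs from compound 1 in one place: chloro in place of fluoro on an aromatic carbon. A halogen swap of this kind, on the aromatic ring at the end of the side chain, is expected to move the number little. The account therefore expects a step from compound 1 to compound 4 of a 1.2-fold lower number from compound 1 to compound 4 (0.06 log units; within the scatter), that is, no change beyond the scatter in either direction. For compound 4 the estimated value is 20 nM, within a range of 7 nM to 60 nM.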

Compound 4, half-maximal effective concentration: 3.3 nM
The estimate for compound 4 lay 6.1-fold (0.78 log units) above the measured number; measured number outside the range, below it.
By their numbers in this assay, from the lowest: compounds 4 and 2 (each within the scatter of the next); then compound 1; then compound 3.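

In this assay, within the data shown here, replacing 2-fluorophenyl with 2-chlorophenyl gives a 7.0-fold lower number from compound 1 to compound 4 (0.84 log units; beyond the scatter), the first step in this set that changes only one place. It shows that this aromatic carbon, ortho to a large group, is sensitive to the identity of its halogen: exchanging one heavy atom for another, with no change in the counted donors, acceptors or net charge, moves the number beyond the scatter. No measurement offered here explains this step.

On these data alone, it remains open whether bromo, methyl, trifluoromethyl or methoxy on the same carbon would continue or reverse this step, and what chloro would do elsewhere on the ring. As far as these compounds go, it is also open whether the same halogen change would have a comparable effect with the longer side chain of compound 2.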